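Bromo to Fluoromethylphenyl: Expected Lipophilicity of Compound 4

This account rests on a few compounds, and the source may have more. Where it says the series, first, only, none or still open, it means among the compounds named here.

Measured so far:
compound 1 `CC[C@@H](Nc1c(C#N)c(-c2ccc(-c3ccccc3CO)cc2)nc2cnccc12)C(N)=O`: 2.1
compound 2 `CC[C@@H](Nc1c(C#N)c(-c2ccc(-c3cccc(C)c3F)cc2)nc2cnccc12)C(=O)O`: 2.1
compound 3 `CC[C@@H](Nc1c(C#N)c(-c2ccc(Br)cc2)nc2cnccc12)C(N)=O`: 2.2

In a physicochemical assay for lipophilicity, read by HPLC, at pH 7.5 (on this read-out higher numbers stand for higher lipophilicity and lower numbers for lower lipophilicity), compound 3 gives 2.2, the highest of the three numbers, though both neighbours lie within the scatter of it. For the measured compounds named here, the only single-point step, a number 0.10 log units higher from compound 1 to compound 3 (within the scatter), shows bromo in place of 2-(hydroxymethyl)phenyl leaving this assay essentially unchanged. Compound 2 carries the group that now enters and gives 2.1, but it differs from compound 4 elsewhere as well.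

Compound 4 `CC[C@@H](Nc1c(C#N)c(-c2ccc(-c3cccc(C)c3F)cc2)nc2cnccc12)C(N)=O` arises from compound 3 by 2-fluoro-3-methylphenyl in place of bromo on an aromatic carbon. Going by the values given here, no measured step covers this swap directly, so the expectation rests on the change itself: an upward step, a number 1.10 log units higher from compound 3 to compound 4 (beyond the scatter), is estimated, clearly beyond the scatter. Compound 4 is therefore expected at 3.3, with a range from 2.7 to 3.9.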

Compound 4, distribution coefficient: 3
Estimate against measurement, compound 4: 0.30 log units above; the range from low to high includes it.
By their numbers in this assay, from the lowest: compounds 1, 2 and 3 (each within the scatter of the next); then compound 4.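

In this assay this position proves sensitive to what sits on it: 2-fluoro-3-methylphenyl in place of bromo gives a number 0.80 log units higher from compound 3 to compound 4 (beyond the scatter) and in place of 2-(hydroxymethyl)phenyl gives a number 0.90 log units higher from compound 1 to compound 4 (beyond the scatter) while those two earlier groups stayed within the scatter of each other. Having a second ring here is therefore not enough, since the particular group matters. On the carbonyl carbon, amino in place of hydroxy gives a number 0.90 log units higher from compound 2 to compound 4 (beyond the scatter) and so a second site also shifts the number.

The compounds shown leave open how a plain phenyl or a methoxy group would read on this aromatic carbon. No measurement at hand says what lies behind these steps.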